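Hydroxy to Amino on Two Related Cores

The compounds below may be only part of what the source reports. "The series", "measured", "known", "first", "only" and "open" are said of these compounds alone.

Compound 1 `COc1cccc(/C=C/c2ccccc2O)c1` and compound 3 `COc1cccc(/C=C/c2ccccc2N)c1` share a core and differ in one group: amino in place of hydroxy on an aromatic carbon. In a functional assay on HT-29 cells (Homo sapiens) for inhibition, read by MTT assay, with a stated time of 2 days (a lower number here means a stronger inhibitor, a higher number a weaker inhibitor), compound 1 gives 26 ug/mL, and compound 3 gives 21.2 ug/mL, a step of a 1.2-fold lower number from compound 1 to compound 3 (0.09 log units; within the scatter). Compound 2 `COc1cccc(/C=C/c2ccc(O)cc2)c1` is built from the same atoms as compound 1 joined differently; the difference between the two cores is not broken down here. In this assay compound 2 gives 26 ug/mL, level with compound 1 at the digits read. Compound 4 `COc1cccc(/C=C/c2ccc(N)cc2)c1` relates to compound 2 by the same kind of change: amino in place of hydroxy on an aromatic carbon. Here the group sits para to a large group, where in compound 3 it sits ortho to a large group. The expected step is a 1.2-fold lower number from compound 2 to compound 4 (0.07 log units; within the scatter), a near-standstill chosen because a 1.2-fold lower number from compound 1 to compound 3 (0.09 log units; within the scatter) lay within the scatter. Compound 4 is therefore estimated at 22 ug/mL, with a likely range from 12 ug/mL to 42 ug/mL.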

Compound 4, half-maximal inhibitory concentration: 16.1 ug/mL
For compound 4 the middle estimate is 1.4-fold (0.14 log units) above the measured one; the measured number falls inside the stated range.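

In this assay, amino in place of hydroxy on the core of compound 2 gives a 1.6-fold lower number from compound 2 to compound 4 (0.21 log units; within the scatter), a small step like the earlier one. Set side by side, the two steps do not differ by more than repeated measurements would: the same change on two cores in this assay, a 1.2-fold lower number (0.09 log units; within the scatter) from compound 1 to compound 3 and a 1.6-fold lower number (0.21 log units; within the scatter) from compound 2 to compound 4, 1.3-fold (0.12 log units) apart, within the scatter of two such steps. The change therefore behaves alike on these two cores, but both steps lie within the scatter, so this does not show that the change alters the number on either core, and two cores cannot speak for the whole series.

The compounds shown leave open whether a different group in the same place, such as a nitrile or a carboxylic acid, would give a step beyond the scatter. They also leave open how amino in place of hydroxy fares on any other core.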